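Trading an amide for an amine on a shared core

The compounds below may be only part of what the source reports. "The series", "measured", "known", "first", "only" and "open" are said of these compounds alone.

Compound 1, `O=C(Nc1ccccc1)c1cnc(NCc2c(F)ccc3c2CCO3)n2cnnc12`, was examined in an ADME assay on microsomes from liver (Homo sapiens) for metabolic stability, read by LC-MS, using NADPH, with stated times of 5 min and 30 min, tested at 1 uM (on this read-out higher numbers stand for fast clearance and lower numbers for slow clearance), where it gives 14 mL.min-1.g-1. Compound 2, `Cc1nc(C(=O)N(C)C)ccc1-c1cnc(NCc2c(F)ccc3c2CCO3)c2cn[nH]c(=O)c12`, shares the same side chain and in this assay gives 19 mL.min-1.g-1. For the measured compounds named here, of these two numbers the one for compound 1 is the lower, yet the gap between compound 1 and compound 2 lies within the scatter of this assay, so the two cannot be told apart on this evidence.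

Compound 3, `Fc1ccc2c(c1CNc1ncc(Nc3ccccc3)c3nncn13)CCO2`, has not yet been measured. It differs from compound 1 in one place: anilino in place of phenylcarbamoyl on an aromatic carbon. Going by the values given here, no pair of measured compounds shows what this exchange does, so the expectation for compound 3 rests only on the number for compound 1 and on the closeness of compound 2 to it.

In this assay compound 3 is therefore expected to land near compound 1, with a step of a 1.1-fold higher number from compound 1 to compound 3 (0.06 log units; within the scatter) that is not expected to exceed the scatter in either direction. The estimate for compound 3 is 16 mL.min-1.g-1, within a range from 6 mL.min-1.g-1 to 40 mL.min-1.g-1.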

Compound 3, intrinsic clearance in microsomes: 20 mL.min-1.g-1
Beside the measured number, compound 3's estimate is 1.3-fold (0.10 log units) below it; the measured number falls inside the stated range.
By their numbers in this assay, from the lowest: compounds 1, 2 and 3 (each within the scatter of the next).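

In this assay, for the compounds shown here, placing anilino instead of phenylcarbamoyl on this aromatic carbon of the shared core gives a 1.4-fold higher number from compound 1 to compound 3 (0.15 log units; within the scatter), the first direct reading of a change at this position. The exchange removes the carbonyl and shortens the group from 9 heavy atoms to 7, while the phenyl ring stays and the counted hydrogen-bond donors and acceptors remain the same, yet the two compounds cannot be told apart on this read-out; for this one pair, then, removing the carbonyl leaves no effect that can be distinguished from ordinary assay variation. The data shown offer no independent measurement that could explain this result.

Going by these compounds alone, only one exchange at this position can be read here, so it remains open whether the same holds on other cores or with a chemically very different group on this carbon, such as a carboxylic acid, a morpholine or a simple methyl. Going by these compounds, it also remains open whether a substituent on the phenyl ring of the anilino group, such as a fluorine or a methoxy group, would produce a step beyond the scatter.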